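A few compounds are considered here, and "the series" means these few. Any claim that something is new, unique, unknown or untested is made for them only; others in the source may bear on it.

Measured compounds:
compound 1 `O=[N+]([O-])c1ccccc1CO[C@@H](CO)[C@H](O)C[S+]1C[C@@H](O)[C@H](O)[C@H]1CO`, 150 nM
compound 2 `CO[C@@H](CO)[C@H](O)C[S+]1C[C@@H](O)[C@H](O)[C@H]1CO`, 2000 nM

In an assay for inhibition of Maltase-glucoamylase (Homo sapiens), using microsomes, with a stated time of 30 min (on this read-out higher numbers stand for weaker inhibition and lower numbers for stronger inhibition), compound 2 stands at the highest of the two numbers, and its nearest neighbour, compound 1, sits at a distance beyond the scatter. Compound 3 `CCO[C@@H](CO)[C@H](O)C[S+]1C[C@@H](O)[C@H](O)[C@H]1CO` is not yet measured. It differs from compound 2 by methyl in place of hydrogen on a saturated chain carbon bound to an oxygen on a saturated carbon; read one bond further out, methoxy becomes ethoxy. Only compound 1 hints at what a larger group at this oxygen does, and it goes far. For compound 3 a small gain is expected, a 1.7-fold lower number from compound 2 to compound 3 (0.22 log units; within the scatter), possibly no larger than the scatter. Compound 3 is estimated at 1200 nM, between 500 nM and 3000 nM.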

Compound 3, half-maximal inhibitory concentration: 960 nM
For compound 3 the middle estimate is 1.3-fold (0.10 log units) above the measured one; the measured number falls inside the stated range.
By their numbers in this assay, from the lowest: compound 1; then compound 3; then compound 2.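

In this assay, lengthening methoxy to ethoxy gives a 2.1-fold lower number from compound 2 to compound 3 (0.32 log units; beyond the scatter) and so, though modest, this single added methyl on the saturated chain carbon already registers beyond the scatter. Going by these compounds alone, this position therefore responds to a change of one carbon, which could not be read from the earlier compounds, as no step linked them. Nothing available here accounts for this gain. Still open, on these data alone, is whether a longer chain, such as propyl or butyl, lowers the number further. Also open, as far as these compounds go, is whether a plain benzyl group, lacking the nitro group, comes close to compound 1 at 150 nM.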